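Swapping chloro for nitro on the shared core

The compounds below may be only part of what the source reports. "The series", "measured", "known", "first", "only" and "open" are said of these compounds alone.

Three compounds share one core and differ only in one group on the aromatic ring. Compound 3 `CC1=CC[C@H](C(C)(C)NC(=S)N/N=C/c2ccccc2Cl)CC1` gives 71300 nM in a functional assay on HT-29 cells (Homo sapiens) for inhibition, read by sulforhodamine B assay, with a stated time of 48 h (a higher number here means a weaker inhibitor of growth, a lower number a stronger inhibitor of growth), the highest of the three numbers. Compound 1 `CC1=CC[C@H](C(C)(C)NC(=S)N/N=C/c2ccccc2)CC1` gives 8800 nM and compound 2 `CC1=CC[C@H](C(C)(C)NC(=S)N/N=C/c2ccccc2O)CC1` gives 10900 nM; here a 1.2-fold higher number from compound 1 to compound 2 (0.09 log units; within the scatter), whereas an 8.1-fold higher number from compound 1 to compound 3 (0.91 log units; beyond the scatter) and a 6.5-fold higher number from compound 2 to compound 3 (0.82 log units; beyond the scatter). Compound 4 `CC1=CC[C@H](C(C)(C)NC(=S)N/N=C/c2ccccc2[N+](=O)[O-])CC1` differs from compound 3 by nitro in place of chloro on an aromatic carbon. Among the compounds with values here, no measured step exchanges chloro for nitro, so the two steps ending at compound 3 show only that the group at this position can move the number by a modest amount. The estimate for compound 4 is therefore 35000 nM, within 9000 nM to 130000 nM. This expectation means a 2.0-fold lower number from compound 3 to compound 4 (0.31 log units; beyond the scatter), a change expected to stay near the scatter.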

Compound 4, concentration for 50% growth inhibition: 7900 nM
Compound 4: middle estimate off by 4.4-fold (0.65 log units), on the high side; measured number below the stated range.
By their numbers in this assay, from the lowest: compounds 4, 1 and 2 (each within the scatter of the next); then compound 3.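

In this assay, nitro in place of chloro gives a 9.0-fold lower number from compound 3 to compound 4 (0.96 log units; beyond the scatter) and so brings back the level of the other compounds, which shows that the high number belongs to chloro and not to every group at this position. Nitro and hydroxy differ by a 1.4-fold lower number from compound 2 to compound 4 (0.14 log units; within the scatter) while nitro and hydrogen differ by a 1.1-fold lower number from compound 1 to compound 4 (0.05 log units; within the scatter) and so, even with its three heavy atoms, nitro does not separate from them. Nothing available explains why chloro alone stands apart. On these data alone, whether fluoro or bromo would follow chloro remains open. So does the effect of an amine or a carboxylic acid on this aromatic carbon.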